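The source may report more compounds than this note shows. Statements on the series, on what has been measured and on what is new or still open speak of the compounds shown alone.

Measured so far:
compound 1 `COc1cccc2cc(C(=O)NCC(=O)O)c(=O)oc12`: 15%
compound 2 `O=C(NCC(O)CO)c1cc2cc(Cl)ccc2oc1=O`: 1%
compound 3 `COc1cccc2cc(C(=O)Nc3c(C#N)ncn3-c3ccc(F)cc3)c(=N)oc12`: 20%

In an assay on HeLa cells for displacement of a labelled ligand from adenosine receptor A3 (Homo sapiens), read by scintillation counting, with a stated time of 180 min, tested at 10 uM (on this read-out lower numbers stand for less inhibition and higher numbers for more inhibition at the one concentration tested (going by the name of the read-out)), compound 3 gives 20%. Compound 1 gives 15%, which lies within the scatter of compound 3. Compound 2 gives 1%, a gap to compound 3 that lies beyond the scatter. Compound 4 `COc1cccc2cc(C(=O)Nc3c(C#N)ncn3-c3ccccc3)c(=N)oc12` is not yet measured in this assay. It differs from compound 3 by hydrogen in place of fluoro on an aromatic carbon. Going by the values given here, no measured pair carries this change, so only the number for compound 3 serves as a guide. The step is expected to be small, none beyond the scatter, in either direction; the expected step is a number 3 percentage points lower from compound 3 to compound 4 (within the scatter). Compound 4 is therefore estimated at 17%, with an expected range from 4% to 32%.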

Compound 4, a percentage reported as inhibition, at one concentration (the size of the read-out at that concentration, not a potency): 40%
For compound 4 the middle estimate is 23 percentage points below the measured one; the whole stated range lies below it.
By their numbers in this assay, from the lowest: compound 2; then compounds 1 and 3 (each within the scatter of the next); then compound 4.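

In this assay, going by these compounds alone, the change from 4-fluorophenyl to phenyl gives a number 20 percentage points higher from compound 3 to compound 4 (beyond the scatter) and is the only single-place step so far. One fluoro on this aromatic carbon, para to a large group, is thus enough to shift the read-out beyond the scatter. No measurement at hand bears on the reason for this step.

On these data alone, one pair gives one direction at one position, so it remains open whether this step is specific to fluoro. A methyl or an amine on the same carbon would show whether other groups track compound 3 or compound 4.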